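Swapping a Halogenated Ring on the Amide Nitrogen

A few compounds are considered here, and "the series" means these few. Any claim that something is new, unique, unknown or untested is made for them only; others in the source may bear on it.

Compound 1 `O=C(c1cncc(N2CC3CC(C2)N3)c1)N1CCc2ccccc2C1` gives 21 nM in an assay on cells for displacement of a labelled ligand from Neuronal acetylcholine receptor; alpha3/beta4 (Homo sapiens); a higher number here means a weaker inhibitor, a lower number a stronger inhibitor.
Compound 2 `O=C(Nc1ccccc1F)c1cncc(N2CC3CC(C2)N3)c1` gives 102 nM in this assay.
Compound 3 `COc1ccc(NC(=O)c2cncc(N3CC4CC(C3)N4)c2)cc1OC` gives 516 nM in this assay.

All three compounds share the same core and differ only in what hangs off the amide. Compound 2 sits in the middle of the three numbers: compound 1 shows a markedly lower value, and compound 3 a markedly higher one, both gaps lying beyond the usual scatter of the measurement. So the group on the amide nitrogen clearly matters for this series, although three points cannot show a rule.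

Compound 4 `O=C(Nc1ccc(Cl)cc1)c1cncc(N2CC3CC(C2)N3)c1` keeps the core of compound 2 and changes only the aromatic ring on the amide nitrogen: 4-chlorophenyl in place of 2-fluorophenyl on an amide-type nitrogen. Both rings carry a single halogen and are otherwise bare, so the change is modest compared with the move to the two-methoxy ring of compound 3. For the measured compounds named here, no measured pair shows this particular swap, so the step can only be guessed from the neighbours.

The expectation is a small step from compound 2 to compound 4 in this assay, most likely towards a slightly higher number but possibly none beyond the scatter: a 1.5-fold higher number from compound 2 to compound 4 (0.17 log units; within the scatter). Compound 4 is therefore estimated at 150 nM, with a plausible range from 50 nM to 500 nM.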

Compound 4, inhibition constant: 123 nM
Beside the measured number, compound 4's estimate is 1.2-fold (0.09 log units) above it; measured number inside the range.
By their numbers in this assay, from the lowest: compound 1; then compounds 2 and 4 (each within the scatter of the next); then compound 3.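

In this assay, replacing 2-fluorophenyl with 4-chlorophenyl on an amide-type nitrogen gives a 1.2-fold higher number from compound 2 to compound 4 (0.08 log units; within the scatter). For the compounds shown here, this is the first direct pair at this position, and it shows that one singly halogenated phenyl ring can take the place of another here without a change that can be read from the measurement. Nothing measured alongside these compounds explains why the two rings give such similar numbers.

This single swap alters both the halogen and its position on the ring, so the two changes cannot be separated, and a 2-chlorophenyl or 4-fluorophenyl group on the same nitrogen would be needed to tell them apart. From the compounds shown here alone, it also remains open how far the number would shift in this assay if the halogen gave way to an amine or a carboxylic acid on the ring, and whether such a compound would stay close to compound 2 at 102 nM.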